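A Sulfonamide Swap on a Shared Core, Tested for Cell Growth

A few compounds are considered here, and "the series" means these few. Any claim that something is new, unique, unknown or untested is made for them only; others in the source may bear on it.

Compound 1 `Cc1ccc(N(C)S(=O)(=O)C2CC3OC2C(c2ccc(NC(=O)CCCCCCC(=O)O)cc2)=C3c2ccc(O)cc2)cc1` was tested in an ADME assay on Vero cells (Chlorocebus sabaeus) for antiproliferative activity, read by MTT assay, with a stated time of 72 h; a higher number here means a weaker inhibitor, a lower number a stronger inhibitor. In this assay compound 1 gives > 100000 nM, which is a limit of the assay and not a number. Compound 2 `Cc1cccc(N(C)S(=O)(=O)C2CC3OC2C(c2ccc(NC(=O)CCCCCCC(=O)O)cc2)=C3c2ccc(O)cc2)c1` differs from compound 1 by a 3-methylphenyl in place of a 4-methylphenyl on a sulfonamide nitrogen. In this assay compound 2 gives > 100000 nM, again a limit. Compound 3 `CN(c1ccccc1Cl)S(=O)(=O)C1CC2OC1C(c1ccc(NC(=O)CCCCCCC(=O)O)cc1)=C2c1ccc(O)cc1` carries a 2-chlorophenyl on a sulfonamide nitrogen. In this assay compound 3 gives > 100000 nM, also a limit. The steps a step that the two limits leave unreadable from compound 1 to compound 2, a step that the two limits leave unreadable from compound 1 to compound 3 and a step that the two limits leave unreadable from compound 2 to compound 3 cannot be sized, because of the limit of > 100000 nM in this assay, at which 3 of the 3 values shown sit.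

Compound 4 `CCN(c1cccc(C)c1)S(=O)(=O)C1CC2OC1C(c1ccc(NC(=O)CCCCCCC(=O)O)cc1)=C2c1ccc(O)cc1` is the untested partner of compound 1, and the change is ethyl(3-methylphenyl)amino in place of methyl(4-methylphenyl)amino on a sulfonyl sulfur. Among the measured compounds shown here, no measured step gives a readable size that bears on this change, since every value so far sits at the same limit. The step that the limit leaves unreadable from compound 1 to compound 4 that the estimate means is expected to leave compound 4 at that limit as well. Compound 4 is therefore estimated at 200000 nM, with a range from 100000 nM to 1000000 nM.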

Compound 4, half-maximal inhibitory concentration: > 100000 nM
Compound 4 ended at the assay's limit; the forecaster's own chance of this, stated with the estimate: 85%; the middle value is on the limit's open side.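

The steps linking compound 4 to compound 1, compound 2 and compound 3 cannot be read, because all four compounds share one limit: the limit of > 100000 nM in this assay, at which 4 of the 4 values shown sit. How these sulfonamide groups compare with one another in this assay stays open, as every result shown is a limit and not a number.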